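This account rests on a few compounds, and the source may have more. Where it says the series, first, only, none or still open, it means among the compounds named here.

Compound 1 `CC(C)N(C)c1ccc2cc(NC(=O)CCc3ccc(C(F)(F)F)cc3)ccc2n1` is the more potent of the two measured compounds. In an assay on isolated protein for displacement of a labelled ligand from melanin-concentrating hormone receptor 1 (Homo sapiens) (a lower number here means a stronger inhibitor, a higher number a weaker inhibitor), compound 1 gives 2 nM, the lowest number of the two. Going by the values given here, its only measured neighbour is compound 2 `O=C(CCc1ccc(C(F)(F)F)cc1)Nc1ccc2nc(N3CC4CC3CO4)ccc2c1`, which in this assay gives 13 nM. Among the compounds with values here, the one measured step, a 6.5-fold higher number from compound 1 to compound 2 (0.81 log units; beyond the scatter), exchanges the acyclic amine on the shared core for a bicyclic amine and weakens binding.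

Compound 3 `O=C(CCc1ccc(C(F)(F)F)cc1)Nc1ccc2nc(N3CCCCCC3)ccc2c1` is not yet measured. It differs from compound 1 in one place: azepan-1-yl in place of isopropyl(methyl)amino on an aromatic carbon

The change is of the same kind as the measured step, an acyclic amine giving way to a cyclic one on the same aromatic carbon of the shared core, but here the ring is a single seven-membered one rather than two five-membered rings. That step weakened binding beyond the scatter, so a move in the same direction is plausible, though a smaller one is expected. The step from compound 1 to compound 3 is therefore expected to be a 2.5-fold higher number from compound 1 to compound 3 (0.40 log units; beyond the scatter). Compound 3 is estimated to give 5 nM in this assay, within a range from 1.5 nM to 16 nM.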

Compound 3, half-maximal inhibitory concentration: 36 nM
The estimate for compound 3 lay 7.2-fold (0.86 log units) below the measured number; measured number above the stated range.
By their numbers in this assay, from the lowest: compound 1; then compound 2; then compound 3.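

Replacing isopropyl(methyl)amino with azepan-1-yl on this aromatic carbon next to the ring nitrogen gives an 18-fold higher number from compound 1 to compound 3 (1.26 log units; beyond the scatter) in this assay, which shows that a single seven-membered ring can cost more at this position than the two five-membered rings did. The step of a 2.8-fold higher number from compound 2 to compound 3 (0.44 log units; beyond the scatter) separates two groups of equal heavy-atom count, so that count alone does not set the number here. Among these three compounds, the acyclic amine of compound 1 gives the lowest number, and both cyclic amines give higher ones, with no compound shown going against that order. Nothing available here explains the size of either step.

The compounds shown leave open whether the oxygen or the two-ring shape of the group in compound 2 accounts for its lower number relative to compound 3, since the two differ in both features at once. They also leave open whether a pyrrolidin-1-yl or piperidin-1-yl ring would come closer to compound 1, and whether a dimethylamino group would keep the low number of the acyclic amine.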